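The source may report more compounds than this note shows. Statements on the series, on what has been measured and on what is new or still open speak of the compounds shown alone.

Compound 1 `COc1cc(NC(=O)Nc2cc(Nc3cc(Br)ccc3OC)ncn2)cc(OC)c1` gives 42.7% in a functional assay on NCI-H226 cells (Homo sapiens) for inhibition, read by MTT assay, with a stated time of 48 h, tested at 10 uM (on this read-out lower numbers stand for less inhibition and higher numbers for more inhibition at the one concentration tested (going by the name of the read-out)), the highest of the three numbers recorded there. Compound 2 `CCc1ccc(Nc2cc(NC(=O)Nc3c(Cl)cccc3Cl)ncn2)cc1` gives 39.5% in this assay, a number that sits within the scatter of compound 1. Compound 3 `COc1ccc(F)cc1Nc1cc(NC(=O)Nc2c(Cl)cccc2Cl)ncn1` gives 31.3% in this assay, which lies beyond the scatter below compound 1. For the measured compounds named here, the one recorded step that changes a single place runs a number 8.2 percentage points lower from compound 2 to compound 3 (within the scatter), and it concerns the same place as the change now considered: the aryl group on the amino nitrogen attached to the shared core.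

Compound 4 `COc1cc(NC(=O)Nc2cc(Nc3cc(C)cc(F)c3)ncn2)cc(OC)c1` differs from compound 1 in that place: 3-fluoro-5-methylphenyl in place of 5-bromo-2-methoxyphenyl on a nitrogen on an aromatic ring. The step from compound 2 to compound 3 swapped that aryl group and stayed within the scatter, so no step beyond the scatter is expected in this assay here either, with at most a slight lowering. Compound 4 is therefore estimated to give 38% in this assay, between 26% and 50%, meaning an expected a number 4.7 percentage points lower from compound 1 to compound 4 (within the scatter).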

Compound 4, a percentage reported as inhibition, at one concentration (the size of the read-out at that concentration, not a potency): 35.3%
Estimate against measurement, compound 4: 2.7 percentage points above; low and high end bracket the measured number.
By their numbers in this assay, from the lowest: compounds 3, 4, 2 and 1 (each within the scatter of the next, the first and the last beyond it).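

The change from 5-bromo-2-methoxyphenyl to 3-fluoro-5-methylphenyl gives a number 7.4 percentage points lower from compound 1 to compound 4 (within the scatter) in this assay on the core of compound 1, so a second aryl exchange on the amino nitrogen, on a different partner core from the earlier one, also stays inside the scatter. This exchange removes the one hydrogen-bond acceptor of the leaving group, and the entering group has none, yet no step beyond the scatter appears in this read-out. Nothing at hand bears on why the number falls where it does.

As far as these compounds go, whether a phenyl group carrying an amine or a carboxylic acid, or a cyclohexyl group, on this nitrogen would give a step beyond the scatter remains open. All these numbers come from one concentration in one cell line, and how the compounds compare in potency remains unsettled.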